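Dropping the Ethyl Group from a Corticotropin-Releasing Factor Binder

The source may hold more compounds than are shown below. What is called first, only, known or untested is meant among the compounds shown, and "the series" means these compounds.

Of the compounds shown here, two have been measured in an assay on isolated protein for binding affinity to corticotropin-releasing factor receptor 1 (Rattus norvegicus); on this read-out higher numbers stand for weaker inhibition and lower numbers for stronger inhibition. Compound 1, `CCc1ccc(N(C)c2nc(C)cc(C)n2)c(Br)c1`, gives 187 nM, the lowest of the two numbers. Compound 2, `Cc1cc(C)nc(N(C)c2ccc(I)cc2)n1`, which carries an iodo group and no ethyl group on its aryl ring, gives 3300 nM, a markedly higher number that lies well beyond the scatter. Compound 3, `Cc1cc(C)nc(N(C)c2ccccc2Br)n1`, keeps the bromo group of compound 1 but loses its ethyl group: the change is hydrogen in place of ethyl on an aromatic carbon. Among the compounds with values here, no measured pair shows this exact change. Compound 2 suggests that an aryl ring bearing only a halogen binds weakly, so a weakening step is expected for compound 3, estimated as an 8.0-fold higher number from compound 1 to compound 3 (0.90 log units; beyond the scatter) in this assay. Compound 3 is therefore expected to give about 1500 nM, most likely between 400 nM and 6000 nM.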

Compound 3, inhibition constant: 5700 nM
Beside the measured number, compound 3's estimate is 3.8-fold (0.58 log units) below it; the measured number falls inside the stated range.
By their numbers in this assay, from the lowest: compound 1; then compounds 2 and 3 (each within the scatter of the next).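

In this assay the change from ethyl to hydrogen, on the ring carbon meta to a bromo group and para to a large group, gives a 30-fold higher number from compound 1 to compound 3 (1.48 log units; beyond the scatter) and lies well beyond the scatter. Within the data shown here, this is the first direct reading of this position, as no earlier pair differed in this one place, and it shows that a substituent of only two carbons here can make a large difference to the number. What lies behind the size of this step is not addressed by any data at hand.

From the compounds shown here alone, only ethyl and hydrogen can be compared at this position, so it remains open how a methyl group, a longer chain such as propyl, or a methoxy group would fare there. A single pair also cannot show whether the step would keep its size with a chloro group in place of the bromo group.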